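The source may report more compounds than this note shows. Statements on the series, on what has been measured and on what is new or still open speak of the compounds shown alone.

Measured so far:

compound 1, `CC(C)(C)OC(=O)N1CCN(C(=S)SCc2cn(-c3ccccc3F)nn2)CC1` — > 128000 nM
compound 2, `S=C(SCc1cn(Cc2ccccc2Cl)nn1)N1CCNCC1` — > 128000 nM

Both compounds were tested in a functional assay on ECa-109 cells (Homo sapiens) for inhibition, read by MTT assay, with a stated time of 72 h; on this read-out lower numbers stand for stronger inhibition and higher numbers for weaker inhibition. In this assay compound 1 gives > 128000 nM, which is a limit of the assay and not a measured number. In this assay compound 2 likewise gives > 128000 nM, again a limit rather than a number. So compound 1 stands at the limit, and the one other value shown sits there too: the limit of > 128000 nM in this assay, at which 2 of the 2 values shown sit. Among the measured compounds shown here, no step between two measured compounds can be read from this.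

Compound 3, `COc1ccc(Cn2cc(CSC(=S)N3CCN(C(=O)OC(C)(C)C)CC3)nn2)cc1`, has not been measured. It differs from compound 1 in one place: 4-methoxybenzyl in place of 2-fluorophenyl on an aromatic nitrogen. With both known values sitting at the limit, there is no measured change on which to build, and the expectation for the step from compound 1 to compound 3 can only be that it is expected to stay beyond the scatter in neither direction, that is a number no higher from compound 1 to compound 3 (the limit leaves the size open). Compound 3 is therefore expected to give about 128000 nM, with a range from 40000 nM to 300000 nM, and most likely only a limit will be reported.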

Compound 3, half-maximal inhibitory concentration: 36800 nM
For compound 3 the middle estimate is 3.5-fold (0.54 log units) above the measured one, and the stated range ends above it.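

Placing 4-methoxybenzyl instead of 2-fluorophenyl on this aromatic nitrogen changes the result in this assay, giving an at least 3.4-fold lower number from compound 1 to compound 3 (0.54 log units; beyond the scatter). The group at this position can therefore bring a compound of this series into the range where the assay returns a number, whereas the earlier compounds gave only a limit: the limit of > 128000 nM in this assay, at which 2 of the 3 values shown sit.

As far as these compounds go, compound 1 gives > 128000 nM, which is a limit and not a number, so the step shows only a minimum size and its true size remains unknown.

This single step also changes several things at once: the fluorine leaves, a methoxy group enters, and phenyl gives way to benzyl, so it cannot show which of these matters. From the compounds shown here alone, it remains open whether an unsubstituted benzyl would give a similar number to compound 3, and whether a benzyl carrying an amine or a carboxylic acid at this position would give a lower or a higher one.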